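The source may hold more compounds than are shown below. What is called first, only, known or untested is meant among the compounds shown, and "the series" means these compounds.

Measured in a functional assay on HCC 2998 cells (Homo sapiens) for antiproliferative activity, read by sulforhodamine B assay, with a stated time of 48 h; a higher number here means a weaker inhibitor of growth, a lower number a stronger inhibitor of growth:
- compound 1 `O=C(NCCCNc1cc(-c2cn(-c3ccccc3)nc2-c2cccc(O)c2)ccn1)Nc1ccc(F)cc1`: 4050 nM
- compound 2 `O=C(NCCCNc1cc(-c2cn(-c3ccccc3)nc2-c2cccc(O)c2)ccn1)Nc1cccc(C(F)(F)F)c1`: 4340 nM

Only these two compounds have been measured, and they lie within the scatter of each other, so compound 1 cannot be ranked ahead of compound 2. Compound 3 `COc1cccc(-c2nn(-c3ccccc3)cc2-c2ccnc(NCCCNC(=O)Nc3ccc(F)cc3)c2)c1` keeps the rest of compound 1 and changes one place, 3-hydroxyphenyl to 3-methoxyphenyl: methyl in place of hydrogen on an oxygen on an aromatic ring. For the measured compounds named here, no measured step touches this oxygen. Going by the values given here, the one step available, a 1.1-fold higher number from compound 1 to compound 2 (0.03 log units; within the scatter), is a change on an amide-type nitrogen instead, so it bears only indirectly. It shows that one change elsewhere on this shared core left the number within the scatter, but it gives no direction for the new change. In this assay, the estimated step is a 1.1-fold higher number from compound 1 to compound 3 (0.05 log units; within the scatter), and no shift beyond the scatter is expected. Compound 3 is estimated at 4500 nM, with an expected range of 1800 nM to 11000 nM.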

Compound 3, concentration for total growth inhibition: 20000 nM
Estimate against measurement, compound 3: 4.4-fold (0.65 log units) below; measured number above the stated range.
By their numbers in this assay, from the lowest: compounds 1 and 2 (each within the scatter of the next); then compound 3.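

In this assay, for the compounds shown here, methyl in place of hydrogen on the oxygen gives a 4.9-fold higher number from compound 1 to compound 3 (0.69 log units; beyond the scatter) and is the first step in this small set to lie beyond the scatter. Going by these compounds alone, the one earlier step, on an amide-type nitrogen, had left the number within the scatter, so the hydroxy to methoxy change is the first sign that the number can respond to a change on this shared core, here toward weaker growth inhibition. Nothing available explains this shift.

The compounds shown cannot separate the loss of the hydrogen on this oxygen from the arrival of the methyl. They also leave open how an amine, a fluorine or an ethoxy group in place of the hydroxy would read, and whether methoxy has the same effect alongside the 3-(trifluoromethyl)phenyl group of compound 2.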